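The compounds below may be only part of what the source reports. "The series", "measured", "known", "first", "only" and "open" are said of these compounds alone.

Compound 1 `COc1cc2c(c(O)c1C(=O)/C=C/c1ccc(OC(=O)c3ccc(OC(F)(F)F)cc3)cc1)CCC(C)(C)O2` and compound 2 `COc1cc2c(c(O)c1C(=O)/C=C/c1ccc(OC(C)=O)cc1)CCC(C)(C)O2` share one core and differ only at a carbonyl carbon. In an assay on HEK293T cells for inhibition of nuclear factor NF-kappa-B complex (Homo sapiens), read by a luciferase reporter (a higher number here means a weaker inhibitor, a lower number a stronger inhibitor), compound 1 gives > 30000 nM, a limit of the assay rather than a number. In this assay compound 2 likewise gives > 30000 nM, again only a limit. The step from one to the other is a step that the two limits leave unreadable from compound 1 to compound 2, and the limit of > 30000 nM in this assay, at which 2 of the 2 values shown sit, leaves compound 2 standing at a limit, with nothing to rank it against. Compound 3 `COc1cc2c(c(OC(C)=O)c1C(=O)/C=C/c1ccc(OC(C)=O)cc1)CCC(C)(C)O2` carries acetyl in place of hydrogen on an oxygen on an aromatic ring. Among the compounds with values here, no measured step covers this change, and both neighbours sit at the limit, so compound 3 is estimated at 40000 nM (range 15000 nM to 120000 nM), a step that the limit leaves unreadable from compound 2 to compound 3 expected to stay within the scatter.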

Compound 3, half-maximal inhibitory concentration: > 30000 nM
Compound 3 ended at the assay's limit (the forecaster's own chance of this, stated with the estimate: 80%); the middle value is on the limit's open side.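

No step can be read from compound 2 to compound 3, and all values shown are limits: the limit of > 30000 nM in this assay, at which 3 of the 3 values shown sit. Going by these compounds, what remains open is how compound 1, compound 2 and compound 3 rank against one another in this assay.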